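Swapping the Halogenated Phenyl Ring of Compound 1

The source may hold more compounds than are shown below. What is called first, only, known or untested is meant among the compounds shown, and "the series" means these compounds.

Measured so far:
Compound 1, `Fc1ccccc1NCn1nc(-c2ccc3c(c2)OCCO3)oc1=S`, 6390 nM
Compound 2, `FC(F)(F)c1ccccc1NCn1nc(-c2ccc3c(c2)OCCO3)oc1=S`, 9220 nM
Compound 3, `FC(F)(F)c1cc(NCn2nc(-c3ccc4c(c3)OCCO4)oc2=S)cc(C(F)(F)F)c1`, 9320 nM

All three compounds share one core and differ only in the aromatic ring attached to the amine nitrogen. In a functional assay, with a stated time of 6 min (a lower number here means a stronger inhibitor, a higher number a weaker inhibitor), compound 1 gives the lowest of the three numbers, but its nearest neighbour, compound 2, sits only a 1.4-fold higher number from compound 1 to compound 2 (0.16 log units; within the scatter) away, which is within the scatter, so no order among these three can be claimed. Among the measured compounds shown here, compound 3 carries two trifluoromethyl groups and gives 9320 nM; no single step connects it to compound 1, so its value shows only that a second trifluoromethyl group did not move the number far from the others.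

Compound 4, `S=c1oc(-c2ccc3c(c2)OCCO3)nn1CNc1cc(Cl)ccc1Cl`, has not yet been measured. Relative to compound 1 the change is 2,5-dichlorophenyl in place of 2-fluorophenyl on an amine nitrogen. For the measured compounds named here, the one step that bears on this, a 1.4-fold higher number from compound 1 to compound 2 (0.16 log units; within the scatter), exchanged one halogen substituent for another on the same ring and stayed within the scatter. On that basis the step from compound 1 to compound 4 is expected to be small, a 1.1-fold higher number from compound 1 to compound 4 (0.04 log units; within the scatter), with no clear direction. The estimate for compound 4 in this assay is therefore 7000 nM, within a range from 3000 nM to 16000 nM.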

Compound 4, half-maximal inhibitory concentration: 5420 nM
Compound 4: middle estimate off by 1.3-fold (0.11 log units), on the high side; the measured number falls inside the stated range.
By their numbers in this assay, from the lowest: compounds 4, 1, 2 and 3 (each within the scatter of the next).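

In this assay, putting 2,5-dichlorophenyl in place of 2-fluorophenyl on the amine nitrogen gives a 1.2-fold lower number from compound 1 to compound 4 (0.07 log units; within the scatter) and so leaves the number within the usual scatter. The earlier step from compound 1 changed only the group on a ring that otherwise stayed the same, whereas this one replaces fluorine with chlorine and the group with 7 heavy atoms by one with 8 heavy atoms. It therefore adds a second kind of change at this place, a different halogen with a different substitution pattern, and this pair shows no measurable effect from it. No measurement is available that could explain why the number stays within the scatter.

All four rings shown are phenyl rings carrying halogen or trifluoromethyl groups, so they sample only a narrow range of what could sit on the amine nitrogen. As far as these compounds go, it remains open whether a phenyl ring carrying a carboxylic acid or an amine, or a cyclohexyl group in place of the phenyl ring, would give a step beyond the scatter.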